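Chloro to Trifluoromethyl on the 2-Chlorophenyl Amide

A few compounds are considered here, and "the series" means these few. Any claim that something is new, unique, unknown or untested is made for them only; others in the source may bear on it.

Measured in a functional assay on HL-60 cells (Homo sapiens) for antiproliferative activity, with a stated time of 24 h; a higher number here means a weaker inhibitor, a lower number a stronger inhibitor:
Compound 1, `NC(=O)c1c(NC(=O)c2ccccc2Cl)sc2c1CCN(C(=S)Nc1ccccc1F)C2`: 4970 nM
Compound 2, `COc1ccccc1NC(=S)N1CCc2c(sc(NC(=O)c3ccccc3Cl)c2C(N)=O)C1`: 40900 nM
Compound 3, `NC(=O)c1c(NC(=O)c2ccccc2Cl)sc2c1CCN(C(=S)Nc1cccnc1)C2`: 33900 nM

Compound 1 gives the lowest number of the three. The two steps away from it are both beyond the scatter: an 8.2-fold higher number from compound 1 to compound 2 (0.92 log units; beyond the scatter) and a 6.8-fold higher number from compound 1 to compound 3 (0.83 log units; beyond the scatter). Between the other two, a 1.2-fold lower number from compound 2 to compound 3 (0.08 log units; within the scatter), so those two are not separable.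

Compound 4, `NC(=O)c1c(NC(=O)c2ccccc2C(F)(F)F)sc2c1CCN(C(=S)Nc1ccccc1F)C2`, differs from compound 1 in one place: trifluoromethyl in place of chloro on an aromatic carbon. Every measured step changes the group on the thiourea nitrogen, while the 2-chlorophenyl amide is kept the same in all three compounds. For the measured compounds named here, no measured step therefore bears on the change from compound 1 to compound 4, and nothing shows how the amide side tolerates a different group.

With no guide, the expected step is a 1.2-fold higher number from compound 1 to compound 4 (0.08 log units; within the scatter), a change not beyond the scatter. Compound 4 is therefore estimated at 6000 nM, within a range from 2000 nM to 20000 nM that allows for the uncertainty.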

Compound 4, half-maximal inhibitory concentration: 23500 nM
For compound 4 the middle estimate is 3.9-fold (0.59 log units) below the measured one; the whole stated range lies below it.
By their numbers in this assay, from the lowest: compound 1; then compounds 4, 3 and 2 (each within the scatter of the next).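

In this assay, for the compounds shown here, the amide side of the molecule proves sensitive to change, which the earlier compounds could not show because they all carried the same 2-chlorophenyl amide. With the 2-fluorophenyl thiourea held constant, replacing the single chlorine atom with the four heavy atoms of trifluoromethyl gives a 4.7-fold higher number from compound 1 to compound 4 (0.67 log units; beyond the scatter), a modest step but one beyond the scatter, so chloro cannot be swapped freely for trifluoromethyl at this carbon. No available evidence explains this loss of activity.

On these data alone, it remains open whether a methyl group, an amine or plain hydrogen at this carbon would match chloro or fall short like trifluoromethyl. Also unknown is whether the same swap costs as much when the thiourea carries 2-methoxyphenyl or pyridin-3-yl instead of 2-fluorophenyl.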